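This account rests on a few compounds, and the source may have more. Where it says the series, first, only, none or still open, it means among the compounds named here.

The compounds here share one core and differ only in the group hung from an oxygen on an aromatic ring. Compound 1 `Nc1ccc2cccc(OC3CCC3)c2n1` carries a cyclobutyl group there. In an assay on cells with melanin-concentrating hormone receptor 1 (Homo sapiens) as the target, read by radioligand binding (on this read-out higher numbers stand for weaker inhibition and lower numbers for stronger inhibition), compound 1 gives > 2000 nM, which is a limit of the assay and not a number. Compound 2 `Nc1ccc2cccc(OCC3CCCC3)c2n1` carries a cyclopentylmethyl group, and in this assay compound 2 gives 53 nM. Compound 3 `CC1CC1COc1cccc2ccc(N)nc12` carries a (2-methylcyclopropyl)methyl group, and in this assay compound 3 gives 1640 nM. Compound 4 `Nc1ccc2cccc(OC3CCCC3)c2n1` has not yet been measured; it differs from compound 1 by cyclopentyl in place of cyclobutyl on an oxygen on an aromatic ring. The step that bears most on it is an at least 37-fold lower number from compound 1 to compound 2 (1.57 log units; beyond the scatter), where a larger ring group on the same oxygen brought a large gain. The step of an at least 1.2-fold lower number from compound 1 to compound 3 (0.08 log units; that floor lies within the scatter) stays within the scatter. Cyclopentyl is a larger ring than cyclobutyl but is joined directly to the oxygen, unlike cyclopentylmethyl, so a gain of intermediate size is expected, an at least 6.6-fold lower number from compound 1 to compound 4 (0.82 log units; beyond the scatter). Compound 4 is expected to give 300 nM in this assay, between 80 nM and 1200 nM.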

Compound 4, half-maximal inhibitory concentration: > 2000 nM
Compound 4: only a limit was reported (the forecaster's own chance of this, stated with the estimate: 10%); at least 6.6-fold (0.82 log units) between middle value and limit.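

The value for compound 4 is a limit of the assay and not a number, and since compound 1 also sits at a limit, the steps from compound 1 to compound 4 cannot be read, so swapping cyclobutyl for cyclopentyl shows no readable gain. Placing cyclopentyl directly on the oxygen instead of cyclopentylmethyl gives an at least 37-fold higher number from compound 2 to compound 4 (1.57 log units; beyond the scatter), so the cyclopentyl ring alone does not bring the strength seen with compound 2, and the saturated chain carbon matters here. Among these compounds, the swap from (2-methylcyclopropyl)methyl to cyclopentyl gives an at least 1.2-fold higher number from compound 3 to compound 4 (0.08 log units; that floor lies within the scatter), which sets no order for that pair.

On these data alone, how the two weakest-reading compounds truly compare stays hidden: the limit of > 2000 nM in this assay, at which 2 of the 4 values shown sit. Whether cyclohexylmethyl or a longer chain such as 2-cyclopentylethyl on the same oxygen would give a lower number also remains open.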